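Shifting the aryl group on the amide chain toward compound 4

A few compounds are considered here, and "the series" means these few. Any claim that something is new, unique, unknown or untested is made for them only; others in the source may bear on it.

Measured so far:
compound 1, `CC(C)C[C@H](N)c1cc(Cl)ccc1N1CCN(C(=O)C(C)Cc2ccc(Cl)cc2)CC1`, 67 nM
compound 2, `CC(C)C[C@H](N)c1cc(C(F)(F)F)ccc1N1CCN(C(=O)C(C)Cc2ccc(Cl)cc2O)CC1`, 36 nM
compound 3, `Cc1ccc(N2CCN(C(=O)[C@H](C)Cc3ccc(Cl)cc3F)CC2)c([C@@H](N)CC(C)C)c1`, 20 nM

In an assay on HEK293 cells for displacement of a labelled ligand from Melanocortin receptor 4 (Homo sapiens) (on this read-out higher numbers stand for weaker inhibition and lower numbers for stronger inhibition), compound 2 gives 36 nM. Among the three numbers this is the second highest: compound 3 sits at a lower number and compound 1 at a higher one, but both gaps are within the usual scatter, so no ordering of the three can be claimed.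

Compound 4, `COc1ccc(CC(C)C(=O)N2CCN(c3ccc(C(F)(F)F)cc3[C@@H](N)CC(C)C)CC2)cc1F`, has not been measured. It differs from compound 2 in a single place: 3-fluoro-4-methoxyphenyl in place of 4-chloro-2-hydroxyphenyl on a saturated chain carbon, two bonds along the chain from a carbonyl carbon. The chain between the carbonyl and the aryl group, and the whole of the core, are unchanged.

Among the measured compounds shown here, no single-change step between measured compounds exists here, so the size of this step rests on expectation alone. A mild move toward a higher number is expected, because compound 1, which likewise carries no hydroxyl on the aryl group, gives 67 nM; the step is estimated at a 1.7-fold higher number from compound 2 to compound 4 (0.22 log units; within the scatter). Compound 4 is therefore expected to give about 60 nM, with a plausible range from 25 nM to 150 nM.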

Compound 4, inhibition constant: 200 nM
The estimate for compound 4 lay 3.3-fold (0.52 log units) below the measured number, outside the stated range (above it).
By their numbers in this assay, from the lowest: compounds 3, 2 and 1 (each within the scatter of the next, the first and the last beyond it); then compound 4.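

In this assay, putting 3-fluoro-4-methoxyphenyl in place of 4-chloro-2-hydroxyphenyl, with the core and the chain unchanged, gives a 5.6-fold higher number from compound 2 to compound 4 (0.74 log units; beyond the scatter), so the aryl group on this chain is a place where the number can move beyond the scatter. The swap changes the hydroxyl, the chlorine, the fluorine and the methoxy together, so this single step cannot show which of them accounts for the weaker inhibition. No measurement on hand explains the step.

The compounds shown leave open how a 4-chloro-2-methoxyphenyl group or an unsubstituted phenyl would read at this place, either of which would help separate the hydroxyl from the other changes. Going by these compounds, it also remains open whether the step would keep its size with the chlorine of compound 1 or the methyl of compound 3 on the core in place of trifluoromethyl.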